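The compounds below may be only part of what the source reports. "The series", "measured", "known", "first", "only" and "open" are said of these compounds alone.

Compound 1 `Oc1ccc(-c2cc(-c3ccoc3)cc(-c3ccccc3O)n2)cc1` gives in a functional assay on HCT-15 cells (Homo sapiens) for cytotoxicity, read by CCK-8 assay (on this read-out lower numbers stand for stronger inhibition and higher numbers for weaker inhibition), a limit of the assay, > 50000 nM. Compound 2 `Oc1ccc(-c2cc(-c3ccoc3)cc(-c3cccc(O)c3)n2)cc1` gives 930 nM. Compound 3 `Oc1ccc(-c2cc(-c3ccoc3)cc(-c3ccc(O)cc3)n2)cc1` gives 1530 nM.

Compound 3 has the higher of the two numbers, its nearest neighbour being compound 2, a 1.6-fold higher number from compound 2 to compound 3 (0.22 log units; within the scatter). The large measured steps, an at least 53-fold lower number from compound 1 to compound 2 (1.73 log units; beyond the scatter) and an at least 32-fold lower number from compound 1 to compound 3 (1.51 log units; beyond the scatter), both start from the limit of > 50000 nM in this assay, at which 1 of the 3 values shown sits, and concern where the hydroxy group sits on one phenyl ring, not the five-membered ring. Compound 4 `Oc1ccc(-c2cc(-c3ccccn3)cc(-c3ccc(O)cc3)n2)cc1` differs from compound 3 in another place: pyridin-2-yl in place of furan-3-yl on an aromatic carbon. Within the data shown here, no measured step touches this position, so the expectation rests on compound 3 alone, and no step beyond the scatter is expected, a 1.0-fold lower number from compound 3 to compound 4 (0.01 log units; within the scatter). Compound 4 is therefore estimated at 1500 nM, in the range 400 nM to 6000 nM.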

Compound 4, half-maximal inhibitory concentration: > 50000 nM
Compound 4: only a limit was reported; the forecaster's own chance of this, stated with the estimate: 10%; at least 33-fold (1.52 log units) between middle value and limit.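

In this assay, the group opposite the ring nitrogen of the shared core also matters: pyridin-2-yl in place of furan-3-yl gives an at least 32-fold higher number from compound 3 to compound 4 (1.51 log units; beyond the scatter). Earlier, only moving a hydroxy group had produced a large step, so this position is not a free place for change. Compound 4 gives a limit of the assay, so the step has a minimum size only: the limit of > 50000 nM in this assay, at which 2 of the 4 values shown sit.

The compounds shown leave open whether ring size or the ring nitrogen counts here. A plain phenyl or a pyridin-3-yl group at this position could separate the two.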